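The source may hold more compounds than are shown below. What is called first, only, known or untested is meant among the compounds shown, and "the series" means these compounds.

Compound 1 `COc1ccc(/C=C/C2CC(=O)C=CO2)cc1`: 204 uM
Compound 2 `COc1ccc(/C=C/C2CC(=O)C=CO2)cc1OC`: 123 uM
Compound 3 `COc1ccc(/C=C/C2CC=CC(=O)N2)cc1`: > 1090 uM

In a functional assay on HT-29 cells (Homo sapiens) for inhibition, read by sulforhodamine B assay, with a stated time of 48 h (a lower number here means a stronger inhibitor of growth, a higher number a weaker inhibitor of growth), compound 1 gives 204 uM. Compound 2 differs from it by methoxy in place of hydrogen on an aromatic carbon, and in this assay compound 2 gives 123 uM, so the step is a 1.7-fold lower number from compound 1 to compound 2 (0.22 log units; within the scatter). Compound 3 carries a different core, and in this assay compound 3 gives only a limit, > 1090 uM; it is the limit of > 1090 uM in this assay, at which 1 of the 3 values shown sits. How the core of compound 3 differs from the core of compound 1 is not broken down here.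

Compound 4 `COc1ccc(/C=C/C2CC=CC(=O)N2)cc1OC` has not been measured in this assay. It differs from compound 3 by methoxy in place of hydrogen on an aromatic carbon, the same change as that from compound 1 to compound 2. That earlier step stayed within the scatter, so for compound 4 a step of similar size is expected, a step that the limit leaves unreadable from compound 3 to compound 4, resting on the step from compound 1 to compound 2 and on the limit of compound 3. Compound 4 is therefore estimated at 1500 uM, within 400 uM to 5000 uM, and a limit rather than a number is the more likely outcome.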

Compound 4, concentration for growth inhibition (reported as GI): > 964 uM
Compound 4 gave a limit, no number (the forecaster's own chance of this, stated with the estimate: 70%); the middle value is on the limit's open side.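

Compound 3 and compound 4 each gave only a limit in this assay, not a number, so the step between them cannot be read. The compounds shown leave open whether methoxy in place of hydrogen on an aromatic carbon changes growth inhibition when it is carried on the core of compound 3.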